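Benzyl para-substituent swap on the shared core

This account rests on a few compounds, and the source may have more. Where it says the series, first, only, none or still open, it means among the compounds named here.

Measured so far:
compound 1 `CNc1nc(NCc2ccc(OC(F)(F)F)cc2)cc(-c2ccccn2)n1` 7 nM
compound 2 `CNc1nc(NCC(C)(C)C)cc(-c2ccccn2)n1` 365 nM
compound 3 `c1ccc(-c2cc(NCC3CC3)ncn2)nc1` 10000 nM

In a functional assay on HEK293 cells for agonist activity at G-protein coupled receptor 39 (Mus musculus), read by inositol phosphate accumulation (a higher number here means that more compound is needed for the effect, a lower number that less compound is needed), compound 1 gives 7 nM, the lowest of the three numbers. Compound 2 gives 365 nM, and compound 3 gives 10000 nM; both gaps to compound 1 are beyond the scatter. Compound 4 `CNc1nc(NCc2ccc(S(C)(=O)=O)cc2)cc(-c2ccccn2)n1` keeps the core of compound 1 and differs only in one place: methylsulfonyl in place of trifluoromethoxy on an aromatic carbon. Among the compounds with values here, no pair measured so far separates this change, so its size is not known from the data. The expected step from compound 1 to compound 4 is an 8.6-fold higher number from compound 1 to compound 4 (0.93 log units; beyond the scatter), an increase beyond the scatter. Compound 4 is therefore estimated at 60 nM, with a range from 10 nM to 400 nM.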

Compound 4, half-maximal effective concentration: 185 nM
Beside the measured number, compound 4's estimate is 3.1-fold (0.49 log units) below it; measured number inside the range.
By their numbers in this assay, from the lowest: compound 1; then compounds 4 and 2 (each within the scatter of the next); then compound 3.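

In this assay, the aromatic carbon para to a large group now has its first measured exchange: methylsulfonyl in place of trifluoromethoxy gives a 26-fold higher number from compound 1 to compound 4 (1.42 log units; beyond the scatter). The position is therefore not indifferent to its substituent, and of these two groups trifluoromethoxy carries the lower number. Nothing available explains the size of this step.

Still open, going by these compounds, is where a chlorine, a nitrile or a methoxy at this place would fall relative to these two groups. Also open, on these data alone, is whether this exchange would give a similar step on another amine side chain.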